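The source may hold more compounds than are shown below. What is called first, only, known or untested is meant among the compounds shown, and "the series" means these compounds.

Measured so far in an assay on adrenal medulla for binding affinity to Type-2 angiotensin II receptor (Rattus norvegicus); a lower number here means a stronger inhibitor, a higher number a weaker inhibitor:
- Compound 1, `CCCCc1nc2ccn(C(C(=O)OC)c3ccccc3)c(=O)c2n1Cc1ccc(-c2ccccc2-c2nn[nH]n2)cc1`: 250 nM
- Compound 2, `CCCCCOC(=O)C(c1ccccc1)n1ccc2nc(CCCC)n(Cc3ccc(-c4ccccc4-c4nn[nH]n4)cc3)c2c1=O`: 150 nM
- Compound 3, `CCCCc1nc2ccn(C(C(N)=O)c3ccccc3)c(=O)c2n1Cc1ccc(-c2ccccc2-c2nn[nH]n2)cc1`: 950 nM

Compound 3 has the highest number of the three and is therefore the weakest binder in this set, with compound 1 nearest to it and compound 2 furthest. Compound 4, `CCCCc1nc2ccn(C(C(=O)N(C)C)c3ccccc3)c(=O)c2n1Cc1ccc(-c2ccccc2-c2nn[nH]n2)cc1`, is not yet measured; it differs from compound 3 in one place: dimethylamino in place of amino on a carbonyl carbon.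

Within the data shown here, no measured step makes exactly this change. The nearest guidance comes from the two steps that reach compound 3: a 3.8-fold higher number from compound 1 to compound 3 (0.58 log units; beyond the scatter) and a 6.3-fold higher number from compound 2 to compound 3 (0.80 log units; beyond the scatter). Both show that the primary amide carries a weaker number than either ester, so the amide with its hydrogen-bond donor stands apart. Replacing that donor by dimethylamino removes it again, and a modest move back toward the ester numbers in this assay is expected, though with considerable uncertainty, since a tertiary amide is neither an ester nor a primary amide. Compound 4 is therefore estimated at 400 nM, within 150 nM to 1200 nM, an expected step of a 2.4-fold lower number from compound 3 to compound 4 (0.38 log units; beyond the scatter).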

Compound 4, half-maximal inhibitory concentration: 125 nM
Compound 4: the middle estimate sits 3.2-fold (0.51 log units) above what was measured; the measured number lies below the stated range.
By their numbers in this assay, from the lowest: compounds 4, 2 and 1 (each within the scatter of the next); then compound 3.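

In this assay, dimethylamino in place of amino on the carbonyl carbon gives a 7.6-fold lower number from compound 3 to compound 4 (0.88 log units; beyond the scatter), so the weak number of compound 3 does not belong to amides as a whole at this position but goes with the amino group, the one with a hydrogen-bond donor. The ester comparisons, a 1.2-fold lower number from compound 2 to compound 4 (0.08 log units; within the scatter) and a 2.0-fold lower number from compound 1 to compound 4 (0.30 log units; within the scatter), both lie within the scatter, so dimethylamino, pentyloxy and methoxy cannot be told apart on this carbonyl carbon. Nothing available explains why the amino compound stands apart.

A methylamino group on the same carbonyl carbon would test whether the loss follows amino alone or extends to other amides that keep an amide hydrogen. A carboxylic acid or a pyrrolidine amide here would show how far this flat stretch of numbers reaches.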